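A few compounds are considered here, and "the series" means these few. Any claim that something is new, unique, unknown or untested is made for them only; others in the source may bear on it.

Of the compounds shown here, three sharing one core have been measured in a functional assay on the whole organism for antagonist activity, with Mus musculus as the target, in the maximal electroshock model; on this read-out higher numbers stand for an effect only at larger amounts of compound and lower numbers for an effect already at smaller amounts. Compound 1 `COC(=O)NC1=NC(c2ccccc2)CN1C` gives 107 mg/kg, compound 2 `CCOC(=O)NC1=NC(c2ccccc2)CN1C` gives 78 mg/kg, and compound 3 `COC(=O)NC1=NC(c2cccc(Cl)c2)CN1C` gives 100 mg/kg. These three numbers all lie within the usual scatter of one another, so the value of compound 3 cannot be separated from either of the other two.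

Compound 4 `CCOC(=O)NC1=NC(c2cccc(Cl)c2)CN1C` is still unmeasured. It differs from compound 3 by a single change: methyl in place of hydrogen on a saturated chain carbon bound to an oxygen next to a carbonyl group. This is methyl in place of hydrogen on a saturated chain carbon bound to an oxygen next to a carbonyl group, so methoxycarbonyl becomes ethoxycarbonyl.

The same change has been measured once before, as a 1.4-fold lower number from compound 1 to compound 2 (0.14 log units; within the scatter). That single precedent bears most directly on the new step. The other measured step, a 1.1-fold lower number from compound 1 to compound 3 (0.03 log units; within the scatter), is chloro in place of hydrogen on an aromatic carbon, and both compound 3 and compound 4 carry that chloro. With one small precedent to go on, no step beyond the scatter is expected in this assay, though a slightly lower number is the likelier direction. The step expected is a 1.4-fold lower number from compound 3 to compound 4 (0.14 log units; within the scatter). For compound 4 the estimated value is 73 mg/kg, with an expected range from 45 mg/kg to 120 mg/kg.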

Compound 4, dose for half-maximal effect: 74 mg/kg
Compound 4: middle estimate off by 1.0-fold (0.01 log units), on the low side; the measured number falls inside the stated range.
By their numbers in this assay, from the lowest: compounds 4, 2, 3 and 1 (each within the scatter of the next).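

In this assay, the change from methoxycarbonyl to ethoxycarbonyl now has a second reading, a 1.4-fold lower number from compound 3 to compound 4 (0.13 log units; within the scatter), this time on a core that carries the chloro, and it agrees with the first reading: the same change on two cores in this assay, a 1.4-fold lower number (0.14 log units; within the scatter) from compound 1 to compound 2 and a 1.4-fold lower number (0.13 log units; within the scatter) from compound 3 to compound 4, 1.0-fold (0.01 log units) apart, within the scatter of two such steps. The chloro can now also be read with ethoxycarbonyl in place, as a 1.1-fold lower number from compound 2 to compound 4 (0.02 log units; within the scatter), and that reading agrees with its earlier one: the same change on two cores in this assay, a 1.1-fold lower number (0.03 log units; within the scatter) from compound 1 to compound 3 and a 1.1-fold lower number (0.02 log units; within the scatter) from compound 2 to compound 4, 1.0-fold (0.01 log units) apart, within the scatter of two such steps. Across these four compounds, each change therefore reads the same whichever form of the other group is present, but every one of these steps lies within the scatter, so the agreement shows only that neither change stands out from the noise of the measurement.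

The compounds shown leave open whether a longer chain, such as propyl, or a chain ending in an amine, placed on the same saturated chain carbon, would give a step beyond the scatter. They also leave open whether a group other than chloro on the aromatic carbon, such as methoxy or a nitrile, would separate from these four numbers.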